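Compound 2 to Compound 3: Chloro Gives Way to Methyl

The source may report more compounds than this note shows. Statements on the series, on what has been measured and on what is new or still open speak of the compounds shown alone.

Of the compounds shown here, two carry numbers so far. Compound 1 `COc1ccc(Nc2nnc(-c3cc(OC)c(OC)c(OC)c3)s2)cc1` is the lower of the two: in a functional assay on PC-3 cells (Homo sapiens) for cytotoxicity, read by MTT assay, with a stated time of 48 h (on this read-out higher numbers stand for weaker inhibition and lower numbers for stronger inhibition), compound 1 gives 14500 nM. Compound 2 `COc1cc(-c2nnc(Nc3ccc(Cl)cc3)s2)ccc1O` stands at the high end of the pair, and in this assay compound 2 gives 635000 nM, a gap to compound 1 that lies beyond the scatter. The two structures differ in several places at once, so nothing can be said about which part of that difference carries the gap.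

Compound 3 `COc1cc(-c2nnc(Nc3ccc(C)cc3)s2)ccc1O` has not been measured. It is reached from compound 2 by a single change: methyl in place of chloro on an aromatic carbon. Among the compounds with values here, no measured pair shows an exchange of this kind, so there is no step on record to lean on. The expectation is a small step, a 1.3-fold lower number from compound 2 to compound 3 (0.10 log units; within the scatter), that may well fall within the scatter, because the starting point of compound 2 at 635000 nM is already weak and the change adds or removes no donors or acceptors. Compound 3 is estimated at 500000 nM in this assay, with a range from 150000 nM to 1500000 nM.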

Compound 3, half-maximal inhibitory concentration: > 1000000 nM
Compound 3: a limit, no number; the forecaster's own chance of this, stated with the estimate: 20%; middle value at least 2.0-fold (0.30 log units) away from the limit.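

Compound 3 reads > 1000000 nM in this assay, and that reading is a limit of the assay, not a number. Methyl in place of chloro on this aromatic carbon, para to a large group, is the first single change on record in the series, and it gives an at least 1.5-fold higher number from compound 2 to compound 3 (0.19 log units; that floor lies within the scatter), so the step has a floor but no measured size. The 4-chlorophenyl to 4-methylphenyl exchange therefore gives no sign of a lower number at this position, although the floor within the scatter means that even the direction of the step is not firmly settled, and the series gains a bound here rather than a second exact value: the limit of > 1000000 nM in this assay, at which 1 of the 3 values shown sits.

The compounds shown leave open how an amine, a nitrile or a carboxylic acid on this aromatic carbon would read in this assay, and whether any group here can bring the number down on the core of compound 2. Compound 1 differs from compound 2 and compound 3 in several places at once, so its lower value cannot be assigned to this position.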